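Swapping the dichlorophenyl for a bromophenyl

The source may hold more compounds than are shown below. What is called first, only, known or untested is meant among the compounds shown, and "the series" means these compounds.

Compound 1 `COc1cc(C(=O)c2sc(-c3ccc(Cl)c(Cl)c3)cc2N)cc(OC)c1OC` carries a 3,4-dichlorophenyl group on the shared core; in a functional assay on CCRF-CEM cells (Homo sapiens) for antiproliferative activity (a lower number here means a stronger inhibitor, a higher number a weaker inhibitor), compound 1 gives 290 nM. Compound 2 `COc1cc(C(=O)c2sc(-c3ccc(I)cc3)cc2N)cc(OC)c1OC` bears a 4-iodophenyl instead, and compound 2 gives 150 nM, so the two numbers lie within the scatter of each other, the step being a 1.9-fold lower number from compound 1 to compound 2 (0.29 log units; within the scatter). Compound 3 `COc1cc(C(=O)c2sc(-c3ccc(Br)cc3)cc2N)cc(OC)c1OC` is not yet measured; it differs from compound 1 by 4-bromophenyl in place of 3,4-dichlorophenyl on an aromatic carbon. For the measured compounds named here, the only measured step that bears on this change, a related halogen swap, stayed within the scatter, so no step beyond the scatter is expected here either. Compound 3 is therefore expected to give 180 nM, within a range from 70 nM to 450 nM. That amounts to an expected step of a 1.6-fold lower number from compound 1 to compound 3 (0.21 log units; within the scatter).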

Compound 3, half-maximal inhibitory concentration: 86 nM
The estimate for compound 3 lay 2.1-fold (0.32 log units) above the measured number; the measured number falls inside the stated range.
By their numbers in this assay, from the lowest: compounds 3, 2 and 1 (each within the scatter of the next, the first and the last beyond it).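

In this assay, for the compounds shown here, this position on the shared core now shows a change beyond the scatter: putting 4-bromophenyl in place of 3,4-dichlorophenyl gives a 3.4-fold lower number from compound 1 to compound 3 (0.53 log units; beyond the scatter), the first such step. Bromo in place of iodo gives a 1.7-fold lower number from compound 2 to compound 3 (0.24 log units; within the scatter), so compound 2 and compound 3 cannot be told apart here. No measurement at hand explains the step from compound 1 to compound 3. Still open, as far as these compounds go, is how a plain phenyl, or a phenyl carrying a methoxy group or an amine in place of the halogen, would behave at this position.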